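2-Ethoxyethyl Replaces Pentan-3-yl: From Compound 3 to Compound 4

This account rests on a few compounds, and the source may have more. Where it says the series, first, only, none or still open, it means among the compounds named here.

Of the compounds shown here, three that share one core have been measured in a functional assay on the whole organism (blood, strain Wistar-Okamoto) with Rattus norvegicus as the target, with a stated time of 5 days; a lower number here means that less compound is needed, a higher number that more compound is needed for the effect. Compound 1, `C/N=C(\NC#N)Nc1cccnc1`, reaches only a limit of > 50 mg/kg in this assay. Compound 2, `CCC/N=C(\NC#N)Nc1cccnc1`, gives 20 mg/kg in this assay. Compound 3, `CCC(CC)/N=C(\NC#N)Nc1cccnc1`, gives 20 mg/kg in this assay, and so stands level with compound 2, the nearest measured neighbour. Among the compounds with values here, the one further value in the set, that of compound 1, is a limit. The measured steps show an at least 2.5-fold lower number from compound 1 to compound 2 (0.39 log units; beyond the scatter) and an at least 2.5-fold lower number from compound 1 to compound 3 (0.39 log units; beyond the scatter), whereas the chain growth gives no change at the digits printed from compound 2 to compound 3 (within the scatter).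

Compound 4, `CCOCC/N=C(\NC#N)Nc1cccnc1`, has not yet been measured. Its structure differs from compound 3 in one place: 2-ethoxyethyl in place of pentan-3-yl on a double-bonded nitrogen. Within the data shown here, the step that bears most on this change is the one from compound 2 to compound 3, where a larger saturated chain on the double-bonded nitrogen left the result within the scatter; no measured step introduces an oxygen into the chain, so that part of the change has no precedent in these data. A step of no change at the digits printed from compound 3 to compound 4 (within the scatter) is therefore expected, that is, no change beyond the scatter. Compound 4 is estimated to give 20 mg/kg in this assay, within a range of 10 mg/kg to 50 mg/kg.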

Compound 4, minimum effective dose: > 20 mg/kg
Compound 4 gave a limit, no number; the forecaster's own chance of this, stated with the estimate: 20%; the middle value sits exactly at the limit.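

In this assay compound 4 gives > 20 mg/kg as a limit and not a number. With the heavy-atom count unchanged at five, 2-ethoxyethyl in place of pentan-3-yl on the double-bonded nitrogen gives a number no lower from compound 3 to compound 4 (the limit leaves the size open) and the companion step gives a number no lower from compound 2 to compound 4 (the limit leaves the size open) so that this first chain bearing an oxygen and a hydrogen-bond acceptor shows no gain over either saturated chain at this position. From the compounds shown here alone, whether the oxygen costs anything here stays unknown because the result for compound 4 is bounded on one side only: the limit of > 20 mg/kg in this assay, at which 1 of the 4 values shown sits.

The step that joins compound 1 and compound 4 cannot be read, and the limit also leaves open whether compound 4 in truth stands level with compound 2 and compound 3. The compounds shown further leave open how a hydroxyl group, an amine or a longer saturated chain on the double-bonded nitrogen would behave in this assay and so whether any group at this position can bring the number lower than the saturated chains do.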